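Pyrazolyl to triazolyl swap on the sulfanylmethyl arm

This account rests on a few compounds, and the source may have more. Where it says the series, first, only, none or still open, it means among the compounds named here.

Measured so far:
compound 1 `N#Cc1c(N)nc(SCc2ccn[nH]2)c(C#N)c1-c1ccc(OCC2CC2)cc1` — an assay on CHO cells for displacement of a labelled ligand from adenosine receptor A3 (Homo sapiens), read by scintillation counting, with a stated time of 120 min, tested at 1 uM; on this read-out higher numbers stand for more inhibition at the one concentration tested (going by the name of the read-out) and lower numbers for less inhibition: 6%
compound 2 `CCOc1ccc(-c2c(C#N)c(N)nc(SCC(N)=O)c2C#N)cc1` — this assay : 20%

Compound 1 stands lowest of the two numbers in this assay; the nearest number, that of compound 2, lies higher by a margin beyond the usual scatter. Among the compounds with values here, no step between two measured compounds is available, so the effect of any single change is unknown here. Compound 3 `N#Cc1c(N)nc(SCn2cncn2)c(C#N)c1-c1ccc(OCC2CC2)cc1` is made from compound 1 by one change: 1H-1,2,4-triazol-1-yl in place of 1H-pyrazol-5-yl on a saturated chain carbon bound to a sulfur. With compound 1 giving 6% in this assay and nothing else to lean on, the expected step is a number 2 percentage points higher from compound 1 to compound 3 (within the scatter), in no clear direction and not beyond the scatter. Compound 3 is therefore estimated at 8%, with a range of 0% to 20%.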

Compound 3, a percentage reported as inhibition, at one concentration (the size of the read-out at that concentration, not a potency): 1%
The estimate for compound 3 lay 7 percentage points above the measured number, and the stated range covers the measured number.
By their numbers in this assay, from the lowest: compounds 3 and 1 (each within the scatter of the next); then compound 2.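

Placing 1H-1,2,4-triazol-1-yl in place of 1H-pyrazol-5-yl on a saturated chain carbon bound to a sulfur gives a number 5 percentage points lower from compound 1 to compound 3 (within the scatter) in this assay, the first single-place step read at this position. Going from 1 hydrogen-bond donor and 1 acceptor to 0 donors and 3 acceptors on this five-membered aromatic ring therefore does not separate the two compounds on this read-out. No evidence bears on this result.

From the compounds shown here alone, whether an amine, a carboxylic acid or a longer chain at this position would separate from compound 1 stays open.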